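Fluoro removed from the aryl ring: compound 2 to compound 3

The source may report more compounds than this note shows. Statements on the series, on what has been measured and on what is new or still open speak of the compounds shown alone.

Compound 1 `COc1cc2ccc(=O)oc2cc1OC(=O)c1c(C)noc1-c1ccc(Cl)cc1` gives 12700 nM in a functional assay on SW-620 cells (Homo sapiens) for inhibition, read by MTT assay, with a stated time of 48 h; a lower number here means a stronger inhibitor, a higher number a weaker inhibitor.
Compound 2 `COc1cc2ccc(=O)oc2cc1OC(=O)c1c(C)noc1-c1ccccc1F` gives > 25000 nM in this assay, a limit of the assay rather than a number.

Compound 2 stands at the limit of the assay (the limit of > 25000 nM in this assay, at which 1 of the 2 values shown sits); of the two values shown, it is the one given only as a limit. Going by the values given here, the step of an at least 1.9-fold higher number from compound 1 to compound 2 (0.29 log units; that floor lies within the scatter) is the single measured step, and its floor lies within the scatter, so no difference beyond the scatter between compound 1 and compound 2 is established.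

Compound 3 `COc1cc2ccc(=O)oc2cc1OC(=O)c1c(C)noc1-c1ccccc1` differs from compound 2 by hydrogen in place of fluoro on an aromatic carbon. Among the compounds with values here, no measured step covers this change: the one measured step exchanges a 4-chlorophenyl for a 2-fluorophenyl, not a fluoro for hydrogen. Both measured values sit at the weak end of the range of the assay, so compound 3 is expected to remain weak as well, with the step of a number no higher from compound 2 to compound 3 (the limit leaves the size open) expected to lie within the scatter. Compound 3 is estimated at 25000 nM, between 10000 nM and 60000 nM, with a fair chance that the assay again reports only a limit.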

Compound 3, half-maximal inhibitory concentration: 23400 nM
Compound 3: middle estimate off by 1.1-fold (0.03 log units), on the high side, and the stated range covers the measured number.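

In this assay compound 3 gives 23400 nM, so the plain phenyl now provides a full number to set against the two halogen-bearing aryl groups at this position. Hydrogen in place of fluoro gives an at least 1.0-fold lower number from compound 2 to compound 3 (0.02 log units; that floor lies within the scatter), and hydrogen in place of chloro gives a 1.8-fold higher number from compound 1 to compound 3 (0.27 log units; within the scatter); neither step establishes a difference, so among these three compounds neither halogen is shown to change the reading in this assay. The fluoro step remains open on one side, because compound 2 is given only as a limit: the limit of > 25000 nM in this assay, at which 1 of the 3 values shown sits.

The three compounds establish no difference at this aryl position, and none of the substituents shown is a clear handle on the number, so it remains unknown whether this position can move the reading beyond the scatter at all. As far as these compounds go, a methoxy group, an amine or a carboxylic acid on the phenyl ring would test this with groups quite unlike fluoro and chloro, and it is also open whether any effect would depend on where on the ring such a group stands.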